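The compounds below may be only part of what the source reports. "The series", "measured", "known", "first", "only" and "open" are said of these compounds alone.

Measured so far:
compound 1 `Cn1nc2c(=O)n(CC3(O)CCN(Cc4ccc(-c5ccco5)cc4Cl)CC3)cnc2c1-c1ccc(C(N)=O)cc1` gives 80.8 nM in an assay on isolated protein for inhibition of ubiquitin carboxyl-terminal hydrolase 7 (Homo sapiens), with stated times of 30 min and 2 h; on this read-out higher numbers stand for weaker inhibition and lower numbers for stronger inhibition;
compound 2 `Cn1nc2c(=O)n(CC3(O)CCN(Cc4ccc(C5=CCCC5)cc4Cl)CC3)cnc2c1-c1ccc(CN)cc1` gives 76.9 nM;
compound 3 `CN(C)Cc1ccc(-c2c3ncn(CC4(O)CCN(Cc5ccc(-c6ccco6)cc5Cl)CC4)c(=O)c3nn2C)cc1` gives 131 nM.

Compound 2 has the lowest number of the three, but its nearest neighbour compound 1 lies within the scatter of it, and even compound 3, the furthest, is within the scatter. So the three compounds cannot be told apart by these numbers.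

Compound 4 `Cn1nc2c(=O)n(CC3(O)CCN(Cc4ccc(-n5ccnc5)cc4Cl)CC3)cnc2c1-c1ccc(CN)cc1` has not yet been measured. It differs from compound 2 in one place: 1H-imidazol-1-yl in place of cyclopent-1-en-1-yl on an aromatic carbon.

Among the compounds with values here, only one measured step is known, a 1.6-fold higher number from compound 1 to compound 3 (0.21 log units; within the scatter), and it concerns a different part of the molecule than the change from compound 2 to compound 4. Within the data shown here, compound 1 and compound 2 differ in two places at once, so their values alone show no step for this position. Among the measured compounds shown here, there is thus no measured step that bears directly on the change, and the safest expectation is a step no larger than the scatter, in no particular direction.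

The estimate for compound 4 is 95 nM, with a range from 40 nM to 230 nM, which amounts to an expected step of a 1.2-fold higher number from compound 2 to compound 4 (0.09 log units; within the scatter).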

Compound 4, half-maximal inhibitory concentration: 228 nM
Compound 4: middle estimate off by 2.4-fold (0.38 log units), on the low side; the measured number falls inside the stated range.
By their numbers in this assay, from the lowest: compounds 2, 1, 3 and 4 (each within the scatter of the next, the first and the last beyond it).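

In this assay, placing 1H-imidazol-1-yl instead of cyclopent-1-en-1-yl on the aromatic carbon para to a large group gives a 3.0-fold higher number from compound 2 to compound 4 (0.47 log units; beyond the scatter), the first step measured at this position. The position is therefore sensitive to which group it carries, even though both groups have 5 heavy atoms and no net charge: a ring of carbon only with a double bond gives way to an aromatic ring with 2 nitrogens and 2 hydrogen-bond acceptors. No measurement shown here explains the size of the step.

From the compounds shown here alone, whether the step follows from the nitrogens or from the change to an aromatic ring stays open, as both changes come together here. A phenyl or 1H-pyrrol-1-yl group on the same carbon, with the rest of compound 4 unchanged, would help to separate the two.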